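From ethylsulfanyl to benzylsulfanyl on the shared core

The compounds below may be only part of what the source reports. "The series", "measured", "known", "first", "only" and "open" are said of these compounds alone.

Compound 1 `COc1ccc(-n2c(S)nnc2-c2cc(OC)c(OC)c(OC)c2)cc1` gives > 60000 nM in a functional assay on PC-3 cells (Homo sapiens) for inhibition, read by MTT assay, with a stated time of 48 h (on this read-out lower numbers stand for stronger inhibition and higher numbers for weaker inhibition), and this is a limit of the assay and not a number. Within the data shown here, compound 2 `CCSc1nnc(-c2cc(OC)c(OC)c(OC)c2)n1-c1ccc(OC)cc1` gives 57700 nM in this assay and so holds the only true number in the set. Compound 3 `COc1ccc(-n2c(SCc3ccccc3)nnc2-c2cc(OC)c(OC)c(OC)c2)cc1` differs from compound 2 by phenyl in place of methyl on a saturated chain carbon bound to a sulfur in the form of ethyl to benzyl, which is phenyl in place of methyl on a saturated chain carbon bound to a sulfur. Among the measured compounds shown here, the only measured step that bears on this is an at least 1.0-fold lower number from compound 1 to compound 2 (0.01 log units; that floor lies within the scatter) with ethyl in place of hydrogen on a sulfur. That step touches the same sulfur but brings in no ring, so it offers little guidance. An estimated 1.6-fold lower number from compound 2 to compound 3 (0.22 log units; within the scatter) is therefore expected, a shift within the scatter that leans only slightly to the lower number. Compound 3 is expected at 35000 nM and from 14000 nM to 60000 nM in four of five measurements.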

Compound 3, half-maximal inhibitory concentration: 34100 nM
For compound 3 the middle estimate is 1.0-fold (0.01 log units) above the measured one; low and high end bracket the measured number.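

In this assay, among these compounds, the sulfur substituent carries a ring for the first time, and the change from ethyl to benzyl gives a 1.7-fold lower number from compound 2 to compound 3 (0.23 log units; within the scatter), so this place accepts phenyl in place of methyl on a saturated chain carbon without a shift beyond the scatter. Putting the benzyl onto the bare sulfur gives an at least 1.7-fold lower number from compound 1 to compound 3 (0.24 log units; that floor lies within the scatter). This step can be read only as a floor, and its true size stays unknown: the limit of > 60000 nM in this assay, at which 1 of the 3 values shown sits.

The compounds shown leave open whether an amine, a carboxylic acid or a longer chain ending in phenyl, set in place of the benzyl on the sulfur, would move the number beyond the scatter. They also leave open whether a chlorine or a methoxy group on the new phenyl ring would change the reading.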